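A few compounds are considered here, and "the series" means these few. Any claim that something is new, unique, unknown or untested is made for them only; others in the source may bear on it.

Compound 3 `COc1ccc(-c2nc3cc(/C=C4\SC(=O)N(CC(=O)N5CCOCC5)C4=O)ccc3[nH]2)cc1OC` has no number of its own in an ADME assay on HEK-293T cells (Homo sapiens) for inhibition, read by MTT assay, with a stated time of 48 h; on this read-out higher numbers stand for weaker inhibition and lower numbers for stronger inhibition: in this assay compound 3 reaches only the limit of the method, > 50000 nM. The two measured steps that lead to it both end at that limit (the limit of > 50000 nM in this assay, at which 1 of the 3 values shown sits). Compound 1 `COc1ccc(-c2nc3cc(/C=C4\SC(=O)NC4=O)ccc3[nH]2)cc1OC`, with hydrogen on the amide-type nitrogen in the ring, gives 21700 nM in this assay, and the step of an at least 2.3-fold higher number from compound 1 to compound 3 (0.36 log units; beyond the scatter) shows what adding ((morpholin-4-yl)carbonyl)methyl there did. Compound 2 `COc1cc(-c2nc3cc(/C=C4\SC(=O)N(CC(=O)N5CCOCC5)C4=O)ccc3[nH]2)cc(OC)c1OC`, carrying one more methoxy on an aromatic carbon, gives 18800 nM, and the step of an at least 2.6-fold higher number from compound 2 to compound 3 (0.42 log units; beyond the scatter) is of similar size.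

Compound 4 `COc1ccc(-c2nc3cc(/C=C4\SC(=O)N(Cc5cc(OC)c(OC)c(OC)c5)C4=O)ccc3[nH]2)cc1OC` differs from compound 3 at the side chain on the ring nitrogen: 3,4,5-trimethoxyphenyl in place of (morpholin-4-yl)carbonyl on a saturated chain carbon bound to an amide-type nitrogen in a ring. Neither measured step changes this place in this way; the step from compound 1 to compound 3 only shows that the morpholine-bearing chain gave a higher number than hydrogen, and compound 2 carries its 3,4,5-trimethoxyphenyl on a different position. So the size and even the direction of the change in this assay are uncertain. Compound 4 is estimated at 30000 nM, within 8000 nM to 100000 nM, which means an expected step of an at least 1.6-fold lower number from compound 3 to compound 4 (0.22 log units; that floor lies within the scatter), with a real chance that only a limit is returned again.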

Compound 4, half-maximal inhibitory concentration: 6760 nM
The estimate for compound 4 lay 4.4-fold (0.65 log units) above the measured number, and the stated range ends above it.
By their numbers in this assay, from the lowest: compound 4; then compounds 2 and 1 (each within the scatter of the next). At a limit, above all of these: compound 3.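

Replacing (morpholin-4-yl)carbonyl with 3,4,5-trimethoxyphenyl on a saturated chain carbon bound to an amide-type nitrogen in a ring gives an at least 7.3-fold lower number from compound 3 to compound 4 (0.86 log units; beyond the scatter) in this assay, so the group at this position can lower the number as well as raise it. Within the data shown here, the only earlier step at this nitrogen ran upward, an at least 2.3-fold higher number from compound 1 to compound 3 (0.36 log units; beyond the scatter), and it could have been read as a penalty for any added side chain, a reading that compound 4 now rules out. The size of the new step is only a floor because compound 3 has a limit rather than a number: the limit of > 50000 nM in this assay, at which 1 of the 4 values shown sits.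

The compounds shown leave open whether the lower number belongs to the phenyl ring itself or to its methoxy groups, a question that a plain phenyl or a phenyl with a single methoxy on the same chain carbon would address. As far as these compounds go, it also remains open how a carboxylic acid, an open-chain amine or a longer chain at this place would read, and whether 3,4,5-trimethoxyphenyl here behaves the same way with the extra methoxy that compound 2 carries on its other aromatic ring.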